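From bromo to cyano on the aromatic ring

A few compounds are considered here, and "the series" means these few. Any claim that something is new, unique, unknown or untested is made for them only; others in the source may bear on it.

In a functional assay on HeLa cells (Homo sapiens) for cytotoxicity, read by MTT assay, with a stated time of 48 h (a higher number here means a weaker inhibitor, a lower number a stronger inhibitor), compound 1 `OC[C@@H]1C[C@H](CO)[C@@H]2C(c3ccc(Cl)cc3)=NO[C@H]12` reads > 50 ug/mL, which is a limit of the assay and not a number. Compound 3 `OC[C@@H]1C[C@H](CO)[C@@H]2C(c3ccc(Br)cc3)=NO[C@H]12` reads > 50 ug/mL, which is also a limit. Among the compounds with values here, compound 2 `Cc1ccc(C2=NO[C@@H]3[C@H](CO)C[C@H](CO)[C@H]23)cc1` gives 26.5 ug/mL, the only true number so far. So compound 3 has no exact value to start from.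

Compound 4 `N#Cc1ccc(C2=NO[C@@H]3[C@H](CO)C[C@H](CO)[C@H]23)cc1` is not yet measured and carries one change: cyano in place of bromo on an aromatic carbon. In words, cyano takes the place of bromo on an aromatic carbon.

The measured steps are swaps on that same carbon. Bromo in place of chloro gave a step that the two limits leave unreadable from compound 1 to compound 3. Methyl in place of chloro gave an at least 1.8-fold lower number from compound 1 to compound 2 (0.27 log units; that floor lies within the scatter), and bromo in place of methyl gave an at least 1.8-fold higher number from compound 2 to compound 3 (0.27 log units; that floor lies within the scatter). All three run into (the limit of > 50 ug/mL in this assay, at which 2 of the 3 values shown sit), and none shows a step beyond the scatter.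

No clear step in either direction is therefore expected in this assay. The estimated step is an at least 1.1-fold lower number from compound 3 to compound 4 (0.04 log units; that floor lies within the scatter), which is expected to stay within the scatter. For compound 4 the estimated value is 45 ug/mL, with an expected range from 20 ug/mL to 90 ug/mL.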

Compound 4, half-maximal inhibitory concentration: > 50 ug/mL
Compound 4: no number, only a limit; the forecaster's own chance of this, stated with the estimate: 55%; middle value at least 1.1-fold (0.04 log units) away from the limit.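

In this assay compound 4 reads > 50 ug/mL, which is a limit of the assay and not a number. Within the data shown here, the one step that can be read is an at least 1.8-fold higher number from compound 2 to compound 4 (0.27 log units; that floor lies within the scatter), while the steps from compound 1 and compound 3 to compound 4 cannot be read. Cyano, which brings a hydrogen-bond acceptor that bromo lacks, is thus a third group on this aromatic carbon to end at the limit, and methyl in compound 2 remains the only group here with a true number: the limit of > 50 ug/mL in this assay, at which 3 of the 4 values shown sit.

Whether methyl truly differs from the other groups stays open, since the step shown does not get beyond the scatter, and how compound 1, compound 3 and compound 4 rank among themselves cannot be told. Also open, on these data alone, is whether an amine, a carboxylic acid or a longer chain on this carbon would give a true number.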